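Swapping 4-chlorophenyl for 3,4-dimethoxyphenyl on a shared core

The compounds below may be only part of what the source reports. "The series", "measured", "known", "first", "only" and "open" are said of these compounds alone.

Compound 1 `Cn1cc(C2CC(c3ccccc3)=NN2C(=O)c2cccnc2)c2ccccc21` gives 4630 nM
Compound 2 `Cn1cc(C2CC(c3ccc(Cl)cc3)=NN2C(=O)c2cccnc2)c2cc(Br)ccc21` gives 5800 nM

Both numbers come from a functional assay on HepG2 cells (Homo sapiens) for inhibition, read by MTT assay, with a stated time of 48 h (on this read-out higher numbers stand for weaker inhibition of growth and lower numbers for stronger inhibition of growth), and lie within the usual scatter of each other, so compound 2 cannot be ranked against compound 1 on this evidence. Compound 3 `COc1ccc(C2=NN(C(=O)c3cccnc3)C(c3cn(C)c4ccc(Br)cc34)C2)cc1OC` has yet to be measured. It carries 3,4-dimethoxyphenyl in place of 4-chlorophenyl on a carbon with a double bond to nitrogen and keeps the rest of compound 2 unchanged. Going by the values given here, no measured pair shows what this swap alone does. Since compound 1 at 4630 nM and compound 2 at 5800 nM sit close together, only a modest shift is expected. The expected step is a 1.2-fold lower number from compound 2 to compound 3 (0.06 log units; within the scatter) and that would stay within the scatter of this assay without a firm direction. For compound 3 the estimated value is 5000 nM with an expected range from 2000 nM to 13000 nM in this test.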

Compound 3, concentration for 50% growth inhibition: 2450 nM
Compound 3: middle estimate off by 2.0-fold (0.31 log units), on the high side; the measured number falls inside the stated range.
By their numbers in this assay, from the lowest: compounds 3, 1 and 2 (each within the scatter of the next, the first and the last beyond it).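

Going by these compounds alone, until now, no pair of compounds isolated the group on the carbon with a double bond to nitrogen. In this assay, 3,4-dimethoxyphenyl in place of 4-chlorophenyl gives a 2.4-fold lower number from compound 2 to compound 3 (0.37 log units; beyond the scatter) on an otherwise unchanged structure, so this position does respond to the group it carries, though the step is modest. No measurement available here explains why this swap has that effect.

From the compounds shown here alone, it remains open whether both methoxy groups are needed or a single one, as in 4-methoxyphenyl, would give the same result, and whether an amine or a carboxylic acid on this phenyl ring would move the number further. It is also unknown whether the same swap would have a similar effect on the core of compound 1.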